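The source may report more compounds than this note shows. Statements on the series, on what has been measured and on what is new or still open speak of the compounds shown alone.

Two compounds of this series have numbers in a functional assay on HCT-116 cells (Homo sapiens) for cytotoxicity, read by MTT assay, with a stated time of 72 h; on this read-out lower numbers stand for stronger inhibition and higher numbers for weaker inhibition. Compound 1, `NS(=O)(=O)c1cc(-c2nnc(CN3CCC(Cc4ccccc4)CC3)o2)c(Cl)cc1SCc1ccccc1`, gives 19000 nM in this assay. Compound 2, `CCOC(=O)c1cn(Cc2nnc(-c3cc(S(N)(=O)=O)c(SCc4ccccc4)cc3Cl)o2)nn1`, gives 108000 nM in this assay, the highest of the two numbers; the gap to compound 1 lies beyond the scatter.

Compound 3, `NS(=O)(=O)c1cc(-c2nnc(/C=C/c3ccc(Br)cc3)o2)c(Cl)cc1SCc1ccccc1`, is not yet measured. Its change from compound 2 is 2-(4-bromophenyl)ethenyl in place of (4-(ethoxycarbonyl)-1H-1,2,3-triazol-1-yl)methyl on an aromatic carbon. Among the compounds with values here, no pair of measured compounds separated by a single change is available, so the step from compound 2 to compound 3 cannot be read from a precedent and only the two numbers above guide it. The expectation is that the number for compound 3 moves toward that of compound 1, a step down from compound 2 of a 4.3-fold lower number from compound 2 to compound 3 (0.64 log units; beyond the scatter) in this assay, beyond the scatter but unsure in size. Compound 3 is therefore estimated at 25000 nM in this assay, with a range from 7000 nM to 80000 nM.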

Compound 3, half-maximal inhibitory concentration: 15000 nM
The estimate for compound 3 lay 1.7-fold (0.22 log units) above the measured number; the measured number falls inside the stated range.
By their numbers in this assay, from the lowest: compounds 3 and 1 (each within the scatter of the next); then compound 2.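

In this assay, within the data shown here, 2-(4-bromophenyl)ethenyl in place of (4-(ethoxycarbonyl)-1H-1,2,3-triazol-1-yl)methyl on this aromatic carbon gives a 7.2-fold lower number from compound 2 to compound 3 (0.86 log units; beyond the scatter), the first step that can be read at this position, and it shows that the number responds to the group placed here. Compound 3 at 15000 nM and compound 1 at 19000 nM lie within the scatter of each other, so two different large groups at this position can share a similar number. Nothing available bears on the cause of this step.

The step exchanges the whole group at once, so the contributions of the bromine, the ethenyl link and the triazole ring cannot be separated. Also open, from the compounds shown here alone, is how a carboxylic acid in place of the ethyl ester of compound 2 would read.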